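Ester chain length in a cytotoxicity series

The source may report more compounds than this note shows. Statements on the series, on what has been measured and on what is new or still open speak of the compounds shown alone.

Measured so far:
compound 1 `CCCCCCCCOC(=O)c1cc(O)c(O)c(O)c1` gives 50000 nM in an ADME assay on CCRF-CEM cells (Homo sapiens) for cytotoxicity; a lower number here means a stronger inhibitor, a higher number a weaker inhibitor
compound 2 `CCCCCCCCCCCCCCOC(=O)c1cc(O)c(O)c(O)c1` gives > 50000 nM in this assay

Compound 2 stands only at a limit of this assay, not at a number, and that is the limit of > 50000 nM in this assay, at which 1 of the 2 values shown sits. The step of a number no lower from compound 1 to compound 2 (the limit leaves the size open) therefore has no readable size. Compound 3 `CCCCCCCCCCOC(=O)c1cc(O)c(O)c(O)c1` differs from compound 2 by hydrogen in place of butyl on a saturated chain carbon, ten or more bonds along the chain from an oxygen next to a carbonyl group. Within the data shown here, only the step from compound 1 to compound 2 bears on this chain region, and it offers no size, so a step within the scatter is expected a number no higher from compound 2 to compound 3 (the limit leaves the size open). Compound 3 is expected to give 50000 nM in this assay, with a range of 20000 nM to 120000 nM.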

Compound 3, half-maximal inhibitory concentration: 9800 nM
Compound 3: middle estimate off by 5.1-fold (0.71 log units), on the high side; measured number below the stated range.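

In this assay, this chain region responds in both directions: ethyl in place of hydrogen gives a 5.1-fold lower number from compound 1 to compound 3 (0.71 log units; beyond the scatter), while hydrogen in place of butyl gives an at least 5.1-fold lower number from compound 2 to compound 3 (0.70 log units; beyond the scatter). Compound 3 is therefore the strongest of the three, and the number does not move steadily one way with chain length. Compound 2 stands at a limit rather than at a number: the limit of > 50000 nM in this assay, at which 1 of the 3 values shown sits.

Still open, going by these compounds, is how far the chain can differ from that of compound 3 before the number rises. On these data alone, whether a shorter chain, or an amide in place of the ester, keeps the number of compound 3 also remains unknown.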